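Swapping methylsulfanyl for methylamino: a cytotoxicity outlook

A few compounds are considered here, and "the series" means these few. Any claim that something is new, unique, unknown or untested is made for them only; others in the source may bear on it.

Three compounds share one core and differ only at a single aromatic carbon. Compound 1 `Nc1nc(NC2CC2)c2ncn(/C=C3/CC3(CO)CO)c2n1` carries cyclopropylamino there; in an ADME assay on Akata cells (Homo sapiens) for cytotoxicity, with a stated time of 7 days (a lower number here means that less compound is tolerated, a higher number that more compound is tolerated), compound 1 gives > 20000 nM, which is a limit of the assay rather than a number. Compound 2 `COCCOc1nc(N)nc2c1ncn2/C=C1/CC1(CO)CO` carries 2-methoxyethoxy; in this assay compound 2 gives > 20000 nM, again a limit. Compound 3 `CSc1nc(N)nc2c1ncn2/C=C1/CC1(CO)CO` carries methylsulfanyl; in this assay compound 3 gives > 20000 nM, also a limit. Because all three sit at the limit of > 20000 nM in this assay, at which 3 of the 3 values shown sit, none of the steps among them can be read in size: a step that the two limits leave unreadable from compound 1 to compound 2, a step that the two limits leave unreadable from compound 1 to compound 3 and a step that the two limits leave unreadable from compound 2 to compound 3. Compound 3 therefore stands level with the other two, at the limit.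

Compound 4 `CNc1nc(N)nc2c1ncn2/C=C1/CC1(CO)CO` differs from compound 3 in one place: methylamino in place of methylsulfanyl on an aromatic carbon. Among the measured compounds shown here, no measured step gives a size for this kind of exchange, since the three steps are unreadable. Three different groups at this carbon all left the compounds tolerated up to the limit, so compound 4 is expected to behave the same way, and the step of a number no higher from compound 3 to compound 4 (the limit leaves the size open) is expected to be none beyond the scatter. The estimate for compound 4 in this assay is 20000 nM, with a range from 10000 nM to 40000 nM, and it is expected most likely to be reported as a limit once more.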

Compound 4, half-maximal cytotoxic concentration: > 24000 nM
Compound 4 was reported as a limit; the forecaster's own chance of this, stated with the estimate: 85%; at least 1.2-fold (0.07 log units) between middle value and limit.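

In this assay compound 4 gives > 24000 nM, again a limit of the assay and not a number. Its steps from compound 1, compound 2 and compound 3 each join two limits, and none can be read in size. The compounds shown leave open at what concentration any of the four harms these cells, and whether the group on this aromatic carbon changes that concentration.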